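This account rests on a few compounds, and the source may have more. Where it says the series, first, only, none or still open, it means among the compounds named here.

Compound 2 `CCCCN1CCC(C(=O)Nc2cc(Cl)c(N)cc2OC)CC1` shares its core with compound 1 `COc1cc(N)c(Cl)cc1NC(=O)C1CCN(CC2CCC2)CC1` and compound 3 `CCOc1ccc(CN2CCC(C(=O)Nc3cc(Cl)c(N)cc3OC)CC2)cc1`; the three differ only in the group on a saturated chain carbon bound to an amine nitrogen in a ring. In a functional assay on the whole organism for antagonist activity, with Mus musculus as the target (a higher number here means that more compound is needed for the effect, a lower number that less compound is needed), compound 2 gives only a limit, > 10 mg/kg, and no number. Compound 1 likewise gives only a limit, > 10 mg/kg. Compound 3, which carries a 4-ethoxyphenyl at that place, gives 6.3 mg/kg. Because of the limit of > 10 mg/kg in this assay, at which 2 of the 3 values shown sit, the step that the two limits leave unreadable from compound 1 to compound 2 cannot be read, while an at least 1.5-fold lower number from compound 2 to compound 3 (0.20 log units; that floor lies within the scatter) and an at least 1.5-fold lower number from compound 1 to compound 3 (0.20 log units; that floor lies within the scatter) show the dose moving downward once an aromatic ring sits there. Compound 4 `COc1cc(N)c(Cl)cc1NC(=O)C1CCN(Cc2ccc(F)cc2)CC1` changes compound 2 in one place: 4-fluorophenyl in place of propyl on a saturated chain carbon bound to an amine nitrogen in a ring. The nearest measured step is an at least 1.5-fold lower number from compound 2 to compound 3 (0.20 log units; that floor lies within the scatter), where an aromatic ring also replaced propyl, so a step of the same direction is expected, an at least 1.6-fold lower number from compound 2 to compound 4 (0.22 log units; that floor lies within the scatter). Compound 4 is therefore estimated to need 6 mg/kg in this assay, within 2.5 mg/kg to 15 mg/kg, with a real chance that only a limit is again returned.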

Compound 4, dose for half-maximal effect: 0.6 mg/kg
Estimate against measurement, compound 4: 10-fold (1.00 log units) above; the measured number lies below the stated range.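

Fluoro in place of ethoxy on the aromatic ring gives an 11-fold lower number from compound 3 to compound 4 (1.02 log units; beyond the scatter), so what the ring carries matters at least as much as the ring itself, and compound 3 did not mark the best this position can give in this assay. Set against the non-aromatic groups, 4-fluorophenyl gives an at least 16-fold lower number from compound 2 to compound 4 (1.22 log units; beyond the scatter) and an at least 16-fold lower number from compound 1 to compound 4 (1.22 log units; beyond the scatter), and these are the first steps from those two compounds that clearly lie beyond the scatter. Both are only floors, and the step between compound 1 and compound 2 still cannot be read, because of: the limit of > 10 mg/kg in this assay, at which 2 of the 4 values shown sit.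

With only ethoxy and fluoro shown on the ring, it remains open how a plain unsubstituted phenyl, a chloro or a methoxy would compare. Also open, on these data alone, is whether a longer chain between the ring and the amine nitrogen would keep this low dose.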